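The source may report more compounds than this note shows. Statements on the series, on what has been measured and on what is new or still open speak of the compounds shown alone.

Compound 2 `Cc1cccc(NC(=O)c2ccc3cccc(O)c3n2)c1` carries a 3-methylphenyl group on an amide-type nitrogen of the shared core. In an ADME assay on THP-1 cells (Homo sapiens) for cytotoxicity, read by WST assay, with a stated time of 24 h (on this read-out higher numbers stand for weaker inhibition and lower numbers for stronger inhibition), compound 2 reaches only the assay limit, > 30000 nM. Compound 1 `Cc1ccccc1NC(=O)c1ccc2cccc(O)c2n1`, with 2-methylphenyl in that place, also gives only the limit, > 30000 nM. The change between them is a step that the two limits leave unreadable from compound 1 to compound 2, so no size can be read from it. Compound 3 `O=C(Nc1ccccc1F)c1ccc2cccc(O)c2n1` differs from compound 2 by 2-fluorophenyl in place of 3-methylphenyl on an amide-type nitrogen. Because (the limit of > 30000 nM in this assay, at which 2 of the 2 values shown sit), compound 3 is expected to behave the same way. The expected step that the limit leaves unreadable from compound 2 to compound 3 is none beyond the scatter. Compound 3 is estimated at 40000 nM, within 15000 nM to 120000 nM.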

Compound 3, half-maximal inhibitory concentration: > 30000 nM
Compound 3: no number, only a limit; the forecaster's own chance of this, stated with the estimate: 85%; the middle value is on the limit's open side.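

For the compounds shown here, compound 3 gives only an assay limit, as do compound 1 and compound 2, so no step among them can be read. The compounds shown leave open what change, if any, would give a measurable value in this assay.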